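This account rests on a few compounds, and the source may have more. Where it says the series, first, only, none or still open, it means among the compounds named here.

Of the compounds shown here, three sharing one core have been tested in an ADME assay on BJ cells (Homo sapiens) for cytotoxicity, with a stated time of 72 h; on this read-out higher numbers stand for an effect only at larger amounts of compound and lower numbers for an effect already at smaller amounts. Compound 1, `CC(=O)c1ccc(NC(=O)Nc2cc(C)nc3ccccc23)cc1`, is the only one of the three for which a number was obtained: in this assay compound 1 gives 22000 nM. Compound 2, `Cc1cc(NC(=O)Nc2cccc3nsnc23)c2ccccc2n1`, reaches only a limit of the assay, and in this assay compound 2 gives > 25000 nM. Compound 3, `Cc1cc(NC(=O)Nc2cccc(C(F)(F)F)c2)c2ccccc2n1`, likewise stops at a limit, and in this assay compound 3 gives > 25000 nM. For the measured compounds named here, compound 1 therefore stands as the single measured number, and it lies close to the limit of > 25000 nM in this assay, at which 2 of the 3 values shown sit. Going by the values given here, no two of these measured compounds differ in just one place, so no measured step can be drawn between them. Compound 4, `COc1ccc(NC(=O)Nc2cc(C)nc3ccccc23)cc1`, has not yet been tested. It differs from compound 1 as follows: methoxy in place of acetyl on an aromatic carbon. Since compound 1 gives 22000 nM, an effect only at large amounts, the step from compound 1 to compound 4 is expected to be a 1.1-fold higher number from compound 1 to compound 4 (0.06 log units; within the scatter), none beyond the scatter. Compound 4 is accordingly estimated at 25000 nM, with a range from 12000 nM to 50000 nM. It is quite possible that this assay will again report only a limit for compound 4.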

Compound 4, half-maximal effective concentration: > 25000 nM
Compound 4 ended at the assay's limit; the forecaster's own chance of this, stated with the estimate: 55%; the middle value sits exactly at the limit.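

In this assay, for the compounds shown here, replacing acetyl with methoxy on an aromatic carbon, para to a large group, gives the first step that can be read between two compounds differing in one place: an at least 1.1-fold higher number from compound 1 to compound 4 (0.05 log units; that floor lies within the scatter). The value for compound 4 is a limit of the assay and not a number, so this step gives only a floor, and no shift towards an effect at smaller amounts of compound appears at this position. Going by these compounds alone, compound 4 joins the compounds that reach only that limit, and the single measured number remains close to it: the limit of > 25000 nM in this assay, at which 3 of the 4 values shown sit.

The compounds shown leave open how far the true value of compound 4 lies from that limit. They also leave open whether an amine or a carboxylic acid at this position would bring the effect down to clearly smaller amounts.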